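Chain extension from compound 3 to compound 4: working notes

The compounds below may be only part of what the source reports. "The series", "measured", "known", "first", "only" and "open" are said of these compounds alone.

Measured compounds in a functional assay on L1210 cells (Mus musculus) for antiproliferative activity; a higher number here means that more compound is needed for the effect, a lower number that less compound is needed:
compound 1 `CCCCCCCCCCCCO/N=C/c1cc(OC)c2c(c1OC)C(=O)C=CC2=O` gives 0.311 ug/mL
compound 2 `CO/N=C/c1cc(OC)c2c(c1OC)C(=O)C=CC2=O` gives 0.109 ug/mL
compound 3 `CCCCCO/N=C/c1cc(OC)c2c(c1OC)C(=O)C=CC2=O` gives 0.175 ug/mL

Compound 3 holds the second highest of the three numbers, but its distance to each neighbour is small: the step of a 1.6-fold higher number from compound 2 to compound 3 (0.21 log units; within the scatter) and the step of a 1.8-fold lower number from compound 1 to compound 3 (0.25 log units; within the scatter) both fall within the scatter, so the three measured compounds cannot be ranked against one another.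

The unmeasured compound 4 `CCCCCCCCCO/N=C/c1cc(OC)c2c(c1OC)C(=O)C=CC2=O` differs from compound 3 by butyl in place of hydrogen on a saturated chain carbon, five bonds along the chain from an oxygen on an unsaturated carbon. Both measured steps bear on this change. The same place is altered in a 1.8-fold lower number from compound 1 to compound 3 (0.25 log units; within the scatter), which runs in the reverse direction and spans a larger group; the same entering group appears in a 1.6-fold higher number from compound 2 to compound 3 (0.21 log units; within the scatter), one bond closer to the oxygen. Neither step leaves the scatter. Compound 4 sits between compound 3 and compound 1 in chain length, and the two steps point, weakly, toward a higher number with a longer chain; no step beyond the scatter is expected in this assay.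

Compound 4 is therefore expected to give 0.23 ug/mL in this assay, with a range from 0.12 ug/mL to 0.45 ug/mL. That estimate amounts to the step of a 1.3-fold higher number from compound 3 to compound 4 (0.12 log units; within the scatter), expected to stay within the scatter.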

Compound 4, concentration for half-maximal effect: 0.19 ug/mL
Compound 4: middle estimate off by 1.2-fold (0.08 log units), on the high side, within the range that was stated.
By their numbers in this assay, from the lowest: compounds 2, 3, 4 and 1 (each within the scatter of the next, the first and the last beyond it).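

In this assay, within the data shown here, butyl in place of hydrogen on a saturated chain carbon, five bonds along the chain from an oxygen on an unsaturated carbon, reads as a 1.1-fold higher number from compound 3 to compound 4 (0.04 log units; within the scatter) and gives no step that can be told from the scatter at this place. Compound 4 also stays within the scatter of both ends of the chain series, with a 1.7-fold higher number from compound 2 to compound 4 (0.24 log units; within the scatter) and with a 1.6-fold lower number from compound 1 to compound 4 (0.21 log units; within the scatter) as its two further steps, so it cannot be ranked against any of the other three compounds. The straight chain can thus be extended at this place without any single step among compounds 2, 3, 4 and 1 leaving the scatter, and only the two ends, compound 2 and compound 1, lie beyond the scatter of each other.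

Still open, on these data alone, is whether a branched chain, or a chain ending in an amine, a carboxylic acid or a phenyl ring, would move the number beyond the scatter at this place, and whether a longer chain than that of compound 1 would do so. Nothing available here explains the small size of these steps.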